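From hydroxy to methoxy on a shared core

The compounds below may be only part of what the source reports. "The series", "measured", "known", "first", "only" and "open" are said of these compounds alone.

Compound 1 `COc1cc(-c2cccc(=O)n2-c2cc(OC)c(OC)c(OC)c2)cc(OC)c1OC` gives 5460 nM
Compound 2 `COc1ccc(-n2c(-c3cc(OC)c(OC)c(OC)c3)cccc2=O)cc1O` gives 1220 nM

Both numbers come from a functional assay on HepG2 cells (Homo sapiens) for cytotoxicity, read by spectrophotometry, with a stated time of 72 h; on this read-out lower numbers stand for stronger inhibition and higher numbers for weaker inhibition. Compound 2 holds the lower of the two, and its gap to compound 1 lies beyond the usual scatter. Compound 3 `COc1ccc(-n2c(-c3cc(OC)c(OC)c(OC)c3)cccc2=O)cc1OC` has not been measured yet. It differs from compound 2 in one place: methyl in place of hydrogen on an oxygen on an aromatic ring, which turns hydroxy into methoxy. Going by the values given here, the only guide is weak, since compound 1 and compound 2 differ in more than this one place. Compound 1, without a hydroxy group, gives 5460 nM, and compound 2, with one, gives 1220 nM. A modest move towards weaker inhibition is therefore expected, an estimated step of a 2.3-fold higher number from compound 2 to compound 3 (0.36 log units; beyond the scatter) that lies only slightly beyond the scatter. Compound 3 is estimated at 2800 nM, within a range of 900 nM to 8000 nM.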

Compound 3, half-maximal inhibitory concentration: 4870 nM
Estimate against measurement, compound 3: 1.7-fold (0.24 log units) below, within the range that was stated.
By their numbers in this assay, from the lowest: compound 2; then compounds 3 and 1 (each within the scatter of the next).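

Turning the hydroxy group into methoxy in this assay gives a clean single-place comparison (a 4.0-fold higher number from compound 2 to compound 3 (0.60 log units; beyond the scatter)), which shows that the hydrogen on this oxygen makes a real difference to the number, although the step is modest. The other single-place change, hydrogen in place of methoxy on an aromatic carbon, behaves differently (a 1.1-fold lower number from compound 1 to compound 3 (0.05 log units; within the scatter)), so compound 1 and compound 3 cannot be told apart in this assay. Nothing available explains why the first change matters and the second does not.

As far as these compounds go, whether an amine or a fluorine in place of the hydroxy group would keep the lower number remains open. So does whether a longer chain on the same oxygen, such as ethoxy, would differ from methoxy.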